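A few compounds are considered here, and "the series" means these few. Any claim that something is new, unique, unknown or untested is made for them only; others in the source may bear on it.

In an assay on membranes from HEK293 cells for displacement of a labelled ligand from Type-2 angiotensin II receptor (Homo sapiens), read by radioligand binding (on this read-out higher numbers stand for weaker inhibition and lower numbers for stronger inhibition), compound 1, `CCCCOC(=O)NS(=O)(=O)c1ccc(CCC)cc1-c1ccc(Cn2c(C(C)(C)C)nc3ccccc32)cc1`, gives 5.3 nM, the lowest of the three numbers in this set. Compound 2, `CCCCOC(=O)NS(=O)(=O)c1ccc(CCC)cc1-c1ccc(Cn2c(CC)nc3ccccc32)cc1`, gives 11 nM in this assay, and compound 3, `CCCCOC(=O)NS(=O)(=O)c1ccc(CCC)cc1-c1ccc(Cn2c(C3CC3)nc3ccccc32)cc1`, gives 31 nM. Both measured steps away from compound 1 run the same way: a 2.1-fold higher number from compound 1 to compound 2 (0.32 log units; beyond the scatter), and a 5.8-fold higher number from compound 1 to compound 3 (0.77 log units; beyond the scatter). The two smaller groups also differ from each other, with a 2.8-fold higher number from compound 2 to compound 3 (0.45 log units; beyond the scatter).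

Compound 4, `CCCCOC(=O)NS(=O)(=O)c1ccc(CCC)cc1-c1ccc(Cn2c(-c3nccs3)nc3ccccc32)cc1`, is not yet measured. It differs from compound 1 in one place: 1,3-thiazol-2-yl in place of tert-butyl on an aromatic carbon. The group that enters sits on an aromatic carbon of a five-membered aromatic ring with 2 nitrogen, part of a fused or bridged system of two rings. Going by the values given here, no measured step exchanges a tert-butyl for an aromatic ring, so the two steps from compound 1 are the only guide, and each of them gave a higher number when tert-butyl was replaced. Compound 4 is therefore expected to give a higher number in this assay than compound 1 does. On that basis compound 4 is expected to show a step of a 3.8-fold higher number from compound 1 to compound 4 (0.58 log units; beyond the scatter). The estimate for compound 4 is 20 nM, within a range from 6 nM to 70 nM.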

Compound 4, inhibition constant: 5.1 nM
Compound 4: middle estimate off by 3.9-fold (0.59 log units), on the high side; measured number outside the range, below it.
By their numbers in this assay, from the lowest: compounds 4 and 1 (each within the scatter of the next); then compound 2; then compound 3.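

In this assay, the position on an aromatic carbon between two ring nitrogen atoms accepts an aromatic ring in place of tert-butyl with no change beyond the scatter (a 1.0-fold lower number from compound 1 to compound 4 (0.02 log units; within the scatter)), so replacing tert-butyl here does not always give a higher number, as compounds 2 and 3 alone had suggested. The same 1,3-thiazol-2-yl group separates compound 4 from both ethyl and cyclopropyl (a 2.2-fold lower number from compound 2 to compound 4 (0.33 log units; beyond the scatter); a 6.1-fold lower number from compound 3 to compound 4 (0.78 log units; beyond the scatter)). Compound 3 and compound 4 both carry a ring at this position. The presence of a ring alone does not set the number. The exchange of tert-butyl for 1,3-thiazol-2-yl also brings in 2 hydrogen-bond acceptors where there were none, but no measurement shown here accounts for what these groups do at this position.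

The compounds shown leave open whether the ring nitrogen and sulfur of the 1,3-thiazol-2-yl group matter, which a plain phenyl or a 2-pyridyl ring at the same carbon could test. They also leave open how this position would respond to an amine or a carboxylic acid.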